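The source may report more compounds than this note shows. Statements on the series, on what has been measured and on what is new or still open speak of the compounds shown alone.

Measured compounds in a functional assay on MCF7 cells (Homo sapiens) for inhibition; on this read-out lower numbers stand for stronger inhibition of growth and higher numbers for weaker inhibition of growth:

Compound 1, `COc1cc(/C=C/C(=O)c2cccc(-n3cc(-c4ccc(Cl)cc4)[nH]c3=O)c2)cc(OC)c1OC`: 1740 nM
Compound 2, `COc1cc(/C=C/C(=O)c2cccc(-n3cc(-c4ccccc4)[nH]c3=O)c2)cc(OC)c1OC`: 310 nM
Compound 3, `COc1ccc(-c2cn(-c3cccc(C(=O)/C=C/c4ccc(O)c(OC)c4)c3)c(=O)[nH]2)cc1`: 3180 nM

Compound 3 stands at the highest number of the three, meaning the weakest growth inhibition; its value is within the scatter of that of compound 1 but lies beyond the scatter from that of compound 2. The unmeasured compound 4, `COc1ccc(-c2cn(-c3cccc(C(=O)/C=C/c4cc(OC)c(OC)c(OC)c4)c3)c(=O)[nH]2)cc1`, differs from compound 3 in one place: 3,4,5-trimethoxyphenyl in place of 4-hydroxy-3-methoxyphenyl on a double-bonded chain carbon bound to a double-bonded chain carbon. Among the compounds with values here, the only measured step, a 5.6-fold lower number from compound 1 to compound 2 (0.75 log units; beyond the scatter), concerns a different part of the molecule, the chloro group on the other aryl ring, and so does not bear directly on this change. What the numbers do show is that both compounds carrying the 3,4,5-trimethoxyphenyl group, compound 1 and compound 2, give lower numbers than compound 3 in this assay, though only the gap to compound 2 is beyond the scatter. On that basis compound 4 is expected to come out with a lower number than compound 3, a step of roughly a 4.0-fold lower number from compound 3 to compound 4 (0.60 log units; beyond the scatter), the estimate for compound 4 being 800 nM with a range from 200 nM to 3200 nM.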

Compound 4, concentration for 50% growth inhibition: 440 nM
For compound 4 the middle estimate is 1.8-fold (0.26 log units) above the measured one; measured number inside the range.
By their numbers in this assay, from the lowest: compounds 2 and 4 (each within the scatter of the next); then compounds 1 and 3 (each within the scatter of the next).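

In this assay, within the data shown here, 3,4,5-trimethoxyphenyl in place of 4-hydroxy-3-methoxyphenyl on a double-bonded chain carbon gives the first direct reading of this change, with the rest of the molecule held the same (a 7.2-fold lower number from compound 3 to compound 4 (0.86 log units; beyond the scatter)). With the 3,4,5-trimethoxyphenyl group present, methoxy in place of hydrogen on an aromatic carbon stays within the scatter (a 1.4-fold higher number from compound 2 to compound 4 (0.15 log units; within the scatter)), while methoxy in place of chloro there is a step beyond it (a 4.0-fold lower number from compound 1 to compound 4 (0.60 log units; beyond the scatter)), so among these three compounds chloro alone stands apart. Nothing available explains these differences.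

Which part of the exchange on the chain counts, the lost hydroxy or the added methoxy, remains open. So does the effect of an amine or a carboxylic acid on that aromatic carbon.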